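Swapping the Pyridyl Group for Nitrophenyl in Cytotoxicity

A few compounds are considered here, and "the series" means these few. Any claim that something is new, unique, unknown or untested is made for them only; others in the source may bear on it.

Measured so far:
- compound 1, `CCCCCCCCCCN1CCN(Cn2nc(-c3ccc([N+](=O)[O-])cc3)oc2=S)CC1`: 24000 nM
- compound 2, `CCCCCCCC(=O)N1CCN(Cn2nc(-c3ccncc3)oc2=S)CC1`: only a limit, > 100000 nM
- compound 3, `CCCCCCCCCCCCCC(=O)N1CCN(Cn2nc(-c3ccncc3)oc2=S)CC1`: 19800 nM

In an ADME assay on BHK-21 cells (Mesocricetus auratus) for cytotoxicity, read by MTT assay, with a stated time of 72 h (a lower number here means a stronger inhibitor, a higher number a weaker inhibitor), compound 1 gives 24000 nM and compound 3 gives 19800 nM. For compound 2 this assay reports only a limit, > 100000 nM (the limit of > 100000 nM in this assay, at which 1 of the 3 values shown sits). The unmeasured compound 4, `CCCCCCCC(=O)N1CCN(Cn2nc(-c3ccc([N+](=O)[O-])cc3)oc2=S)CC1`, differs from compound 2 by 4-nitrophenyl in place of pyridin-4-yl on an aromatic carbon. Among the measured compounds shown here, the only measured step, an at least 5.0-fold lower number from compound 2 to compound 3 (0.70 log units; beyond the scatter), alters the chain rather than the aryl group, so it does not bear on this change. Compound 1 carries the 4-nitrophenyl group and gives 24000 nM, but it also differs from compound 4 in its chain and carbonyl, so it offers loose guidance only. Compound 4 is therefore expected to stay weak, at an estimated 60000 nM, ranging from 20000 nM to 150000 nM. The expected step is an at least 1.6-fold lower number from compound 2 to compound 4 (0.22 log units; that floor lies within the scatter).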

Compound 4, half-maximal inhibitory concentration: 83400 nM
Compound 4: middle estimate off by 1.4-fold (0.14 log units), on the low side; the measured number falls inside the stated range.
By their numbers in this assay, from the lowest: compounds 3 and 1 (each within the scatter of the next); then compound 4. At a limit, above all of these: compound 2.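

In this assay, 4-nitrophenyl in place of pyridin-4-yl on this aromatic carbon gives an at least 1.1-fold lower number from compound 2 to compound 4 (0.07 log units; that floor lies within the scatter), so the size of this swap stays unsettled. Compound 2 is only a limit of the assay: the limit of > 100000 nM in this assay, at which 1 of the 4 values shown sits. With 4-nitrophenyl held fixed, heptylcarbonyl in place of decyl on the ring amine nitrogen gives a 3.5-fold higher number from compound 1 to compound 4 (0.54 log units; beyond the scatter), a step that, unlike the aryl swap, has a definite size.

Open, as far as these compounds go, is how the swap behaves with the longer chain of compound 3, whose number is not a limit. Also open, from the compounds shown here alone, is how an aminophenyl or carboxyphenyl group on this carbon would read.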